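Bromo in place of the substituted phenyl group

This account rests on a few compounds, and the source may have more. Where it says the series, first, only, none or still open, it means among the compounds named here.

Measured so far in a functional assay on MGC-803 cells (Homo sapiens) for antiproliferative activity, read by CellTiter-Glo, with a stated time of 72 h (a lower number here means a stronger inhibitor, a higher number a weaker inhibitor), for this series
compound 1 `O=C(NO)c1ccc(/C=C/c2ccnc(-c3ccccc3O)c2)cc1` at 1420 nM
compound 2 `Cc1ccc(-c2cc(/C=C/c3ccc(C(=O)NO)cc3)ccn2)c(F)c1` at 770 nM

For the measured compounds named here, compound 2 is not separated from compound 1, its only neighbour, as the two values lie within the scatter of each other. The next compound is compound 3 `O=C(NO)c1ccc(/C=C/c2ccnc(Br)c2)cc1` with the change bromo in place of 2-fluoro-4-methylphenyl on an aromatic carbon and here bromo takes the place of 2-fluoro-4-methylphenyl next to the ring nitrogen. Going by the values given here, the one measured step that bears on this is a 1.8-fold lower number from compound 1 to compound 2 (0.27 log units; within the scatter) and it exchanges one substituted phenyl group for another. Among the compounds with values here, no measured compound lacks that ring, so the guide is weak. In this assay a small step toward a higher number is expected, with none beyond the scatter. The estimate for compound 3 is 1500 nM with an expected range from 500 nM to 4500 nM as a wide allowance. This estimate means a 1.9-fold higher number from compound 2 to compound 3 (0.29 log units; within the scatter) as the expected step.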

Compound 3, half-maximal inhibitory concentration: > 10000 nM
Compound 3 ended at the assay's limit (the forecaster's own chance of this, stated with the estimate: 5%); middle value at least 6.6-fold (0.82 log units) away from the limit.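

In this assay compound 3 gives > 10000 nM, which is a limit of the assay and not a number: the limit of > 10000 nM in this assay, at which 1 of the 3 values shown sits.
Bromo in place of the substituted phenyl group next to the ring nitrogen gives an at least 12-fold higher number from compound 2 to compound 3 (1.11 log units; beyond the scatter), and against the 2-hydroxyphenyl group it gives an at least 7.0-fold higher number from compound 1 to compound 3 (0.84 log units; beyond the scatter). For the compounds shown here, the earlier pair differed only in the substituents on that phenyl group and stayed within the scatter of each other, whereas this change removes the six-membered aromatic ring of carbon only and is the first step at this position beyond the scatter.

On these data alone, whether a ring is needed at this position, or whether a non-aromatic group larger than bromo would serve, remains open; a morpholine or a short alkyl chain there would bear on that. The compounds shown also leave open how far an unsubstituted phenyl group would hold the values of compound 1 and compound 2.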